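The compounds below may be only part of what the source reports. "The series", "measured", "known", "first", "only" and "open" are said of these compounds alone.

Working notes on the series. All four compounds share one core, an imidazoline-bearing ether on a benzene ring; they differ only in the group on that ring. Compound 1 `CCN(CC)C(=O)c1ccccc1OCC1=NCCN1` carries a diethylamide there, and in a functional assay for activation of Alpha-1A adrenergic receptor (Homo sapiens), read by calcium flux (on this read-out lower numbers stand for an effect already at smaller amounts and higher numbers for an effect only at larger amounts of compound), compound 1 returns only a limit of the assay, < 5020 nM. Compound 2 `Cc1cccnc1-c1ccccc1OCC1=NCCN1` carries a methylpyridine, and in this assay compound 2 likewise returns a limit rather than a number, < 100000 nM. Among the compounds with values here, compound 3 `c1coc(-c2ccccc2OCC2=NCCN2)c1` carries a furan-2-yl, and in this assay compound 3 gives 1.26 nM, the only actual number among the three values. Within the data shown here, the values of compound 1 and compound 2 are limits, so no step between measured compounds can be drawn from them.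

Compound 4 `Cc1ccoc1-c1ccccc1OCC1=NCCN1` differs from compound 3 in a single place: methyl in place of hydrogen on an aromatic carbon, which read one bond further out is furan-2-yl to 3-methylfuran-2-yl. Among the measured compounds shown here, no measured pair in the set shows what such a change does.

For compound 4 the step in this assay is expected to stay within the usual scatter, a 1.6-fold higher number from compound 3 to compound 4 (0.20 log units; within the scatter), with no direction claimed. Compound 4 is therefore estimated in this assay at 2 nM, in a range from 0.4 nM to 12 nM.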

Compound 4, half-maximal effective concentration: 3.16 nM
Compound 4: middle estimate off by 1.6-fold (0.20 log units), on the low side; measured number inside the range.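

In this assay, within the data shown here, the change from furan-2-yl to 3-methylfuran-2-yl gives a 2.5-fold higher number from compound 3 to compound 4 (0.40 log units; beyond the scatter) and is the only measured reading of a substitution at this position, on the aromatic carbon next to the ring atom that bears a large group. The position therefore accepts a methyl at a modest cost on this read-out: compound 4 gives 3.16 nM in this assay and remains a number rather than a limit. Nothing in the data at hand bears on the reason for this step.

This is a single pair with a single substituent, so it sets no trend for the position. As far as these compounds go, whether an ethyl, a methoxy, an amine or a carboxylic acid in place of the methyl would keep a comparable number in this assay stays open.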